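A few compounds are considered here, and "the series" means these few. Any claim that something is new, unique, unknown or untested is made for them only; others in the source may bear on it.

Measured compounds in an in vitro functional assay on HEK293-A cells for positive allosteric modulation of metabotropic glutamate receptor 5 (Homo sapiens), read by FLIPR and calcium flux; a lower number here means that less compound is needed, a higher number that more compound is needed for the effect:

compound 1, `O=C1CC(c2nc(-c3cccc(Cl)c3)no2)CN1c1cccc(Cl)c1`: > 10000 nM, a limit of the assay.
compound 2, `O=C1CC(c2nc(-c3cccc(Cl)c3)no2)CN1c1ccc(Cl)c(Cl)c1`: 460 nM.
compound 3, `O=C1CC(c2nc(-c3cccc(Cl)c3)no2)CN1c1ccccc1Cl`: > 10000 nM, a limit of the assay.

For the measured compounds named here, compound 2 holds the only number among the three values; the other two sit at the limit of > 10000 nM in this assay, at which 2 of the 3 values shown sit. Within the measured set, all changes sit on the aryl attached to the amide-type nitrogen in the ring: an at least 21-fold lower number from compound 1 to compound 2 (1.33 log units; beyond the scatter), and an at least 21-fold higher number from compound 2 to compound 3 (1.33 log units; beyond the scatter), both large. The step from compound 1 to compound 3 is a step that the two limits leave unreadable from compound 1 to compound 3.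

Compound 4, `O=C1CC(c2nc(-c3ccc(Cl)cc3)no2)CN1c1ccc(Cl)c(Cl)c1`, differs from compound 2 elsewhere: 4-chlorophenyl in place of 3-chlorophenyl on an aromatic carbon. Going by the values given here, no measured step touches this aryl, so the steps above give no direct bearing on it. Going by these compounds, with the 3,4-dichlorophenyl on the ring nitrogen kept as in compound 2, the working expectation is a number close to that of compound 2, with a wide range because the position of the chlorine on this aryl is untested here. The step from compound 2 to compound 4 in this assay is therefore expected to be a 1.5-fold higher number from compound 2 to compound 4 (0.18 log units; within the scatter). For compound 4 the estimated value in this assay is 700 nM, expected between 200 nM and 4000 nM.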

Compound 4, half-maximal effective concentration: 1100 nM
Beside the measured number, compound 4's estimate is 1.6-fold (0.20 log units) below it; the range from low to high includes it.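

For the compounds shown here, this is the first measured change on the aryl held on the five-membered aromatic ring with 2 nitrogen and 1 oxygen; all earlier steps sat on the aryl on the ring nitrogen. In this assay, moving the chlorine within this aryl, with the same atoms and the same counts, gives a 2.4-fold higher number from compound 2 to compound 4 (0.38 log units; beyond the scatter). The placement of the chlorine on this aryl therefore registers in the read-out, but the step is modest, whereas the readable steps on the other aryl are large, and compound 4 keeps a measurable number. Nothing on hand accounts for this shift.

Going by these compounds, what a methoxy group, a nitrile or an amine on this aryl would give remains open, as does a pyridyl ring in place of the phenyl. Also open, on these data alone, is whether the same order between 3-chlorophenyl and 4-chlorophenyl holds with a different aryl on the ring nitrogen.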